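Extending the amide chain from pentyl to phenylbutyl on the shared core

A few compounds are considered here, and "the series" means these few. Any claim that something is new, unique, unknown or untested is made for them only; others in the source may bear on it.

Compound 3, with structure `CCCCCNC(=O)n1c(=O)oc2cc(C3CCN(C)CC3)ccc21`, is the starting point of this account. In a physicochemical assay for solubility, read by HPLC, in phosphate buffer, measured as kinetic solubility, with a stated time of 1 h, at pH 7.4, tested at 250 uM (on this read-out higher numbers stand for higher solubility and lower numbers for lower solubility), compound 3 gives 240000 nM, the highest of the two numbers reported so far. Its nearest neighbour is compound 1, with structure `CCN1CCC(c2ccc3c(c2)oc(=O)n3C(=O)NCCCCc2ccccc2)CC1`, which in this assay gives 198000 nM, a value that sits within the scatter of compound 3. Compound 2, with structure `CC(C)CN1CCC(c2ccc3c(c2)oc(=O)n3C(=O)NCCCCc2ccccc2)CC1`, in this assay gives only a limit of < 1000 nM. Within the data shown here, the one measured step, an at least 190-fold lower number from compound 1 to compound 2 (2.29 log units; beyond the scatter), concerns the substituent on the amine nitrogen in the ring and does not touch the part of the molecule changed here, since the evidence at the limit of < 1000 nM in this assay, at which 1 of the 3 values shown sits, only marks where that value ends. Compound 4, with structure `CN1CCC(c2ccc3c(c2)oc(=O)n3C(=O)NCCCCc2ccccc2)CC1`, differs from compound 3 by phenyl in place of methyl on a saturated chain carbon, four bonds along the chain from an amide-type nitrogen. Among the measured compounds shown here, no measured step bears on this change; compound 1 already carries the phenylbutyl chain and remains close to compound 3. Compound 4 is therefore expected to show a 1.3-fold lower number from compound 3 to compound 4 (0.12 log units; within the scatter). The estimate for compound 4 in this assay is 180000 nM, in a range from 70000 nM to 320000 nM.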

Compound 4, solubility: 120000 nM
Estimate against measurement, compound 4: 1.5-fold (0.18 log units) above, within the range that was stated.
By their numbers in this assay, from the lowest: compounds 4, 1 and 3 (each within the scatter of the next). At a limit, below all of these: compound 2.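

Phenyl in place of methyl at the chain end reads as a 2.0-fold lower number from compound 3 to compound 4 (0.30 log units; within the scatter) in this assay, so with the substituent on the ring amine held fixed, the phenylbutyl chain on its own gives no step beyond the scatter. With that chain in place, hydrogen in place of methyl on the carbon bound to the ring amine nitrogen reads as a 1.7-fold lower number from compound 1 to compound 4 (0.22 log units; within the scatter), which shows compound 1 and compound 4 side by side within the scatter. Hydrogen in place of isopropyl at that carbon reads as an at least 120-fold higher number from compound 2 to compound 4 (2.07 log units; beyond the scatter), a step that rests on a limit: the limit of < 1000 nM in this assay, at which 1 of the 4 values shown sits.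

The compounds shown leave open how a shorter chain between the phenyl and the amide nitrogen, or an amine or a carboxylic acid on the phenyl, would read. They also leave open where between ethyl and the substituent of compound 2 the number falls, for instance with a propyl group on the ring amine nitrogen.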